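The source may report more compounds than this note shows. Statements on the series, on what has been measured and on what is new or still open speak of the compounds shown alone.

Of the compounds shown here, three sharing one core have been measured in a functional assay on A-375 cells (Homo sapiens) for antiproliferative activity, read by CCK-8 assay, with a stated time of 72 h, tested at 2 uM; a higher number here means a stronger effect of the compound at the concentration tested, a lower number a weaker effect. Compound 1, `Nc1ccccc1NC(=O)c1ccc(CSC(=S)N2CCN(C(c3ccccc3)c3ccccc3)CC2)cc1`, gives 8.7%. Compound 2, `Nc1ccccc1NC(=O)c1ccc(CSC(=S)N2CCN(c3ccc(Cl)cc3)CC2)cc1`, gives 32.2%. Compound 3, `CN1CCN(C(=S)SCc2ccc(C(=O)Nc3ccccc3N)cc2)CC1`, gives 36.6%. Among these three numbers compound 2 stands second highest: compound 3 lies close, with a number 4.4 percentage points higher from compound 2 to compound 3 (within the scatter), whereas the number for compound 1 lies far lower, beyond the scatter.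

Compound 4, `Nc1ccccc1NC(=O)c1ccc(CSC(=S)N2CCN(Cc3cccnc3)CC2)cc1`, has not yet been measured. It differs from compound 2 in one place: (pyridin-3-yl)methyl in place of 4-chlorophenyl on an amine nitrogen in a ring. Among the measured compounds shown here, the only measured step at this same position is the one from compound 2 to compound 3, where the whole 4-chlorophenyl group was exchanged for methyl, and that step stayed within the scatter. Compound 1, which carries a much larger group on that same ring nitrogen, shows the low number, but no single-step comparison to compound 2 exists for it, so its value can only be noted. With one flat step and one unconnected low number, no shift beyond the scatter is expected in this assay for compound 4. The estimated step is therefore a number 2.2 percentage points lower from compound 2 to compound 4 (within the scatter). Compound 4 is expected to reach about 30%, within a range from 12% to 46%.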

Compound 4, a percentage reported as inhibition, at one concentration (the size of the read-out at that concentration, not a potency): 31.5%
Compound 4: middle estimate off by 1.5 percentage points, on the low side; the measured number falls inside the stated range.
By their numbers in this assay, from the lowest: compound 1; then compounds 4, 2 and 3 (each within the scatter of the next).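

In this assay, the ring nitrogen now carries a third kind of group, and swapping 4-chlorophenyl for (pyridin-3-yl)methyl gives a number 0.7 percentage points lower from compound 2 to compound 4 (within the scatter), so a ring with one hetero atom and one hydrogen-bond acceptor cannot be told apart from a carbon-only ring bearing chlorine. The second new comparison, which places pyridin-3-yl on the methyl group, gives a number 5.1 percentage points lower from compound 3 to compound 4 (within the scatter), so adding this aromatic ring to that carbon also produces no step beyond the scatter. Methyl, 4-chlorophenyl and (pyridin-3-yl)methyl therefore give matching numbers at this ring nitrogen, whereas compound 1, with its much larger group, stands apart at 8.7%.

Nothing available explains why these three groups give such similar numbers. Still open, from the compounds shown here alone, is how a carboxylic acid, a primary amine or a longer chain between the ring nitrogen and the pyridine ring would read at this position, and since each number comes from a single concentration, whether compounds 2, 3 and 4 would differ in the strength of their effect at any other concentration also remains unknown.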